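From Chloro to Methyl on a Shared Core

The source may report more compounds than this note shows. Statements on the series, on what has been measured and on what is new or still open speak of the compounds shown alone.

Three compounds share one core and differ in a single halogen: compound 1 (`Fc1ccc2[nH]c(-c3cn(-c4ccccc4)nc3-c3ccccc3)nc2c1`) carries fluoro, compound 2 (`Clc1ccc2[nH]c(-c3cn(-c4ccccc4)nc3-c3ccccc3)nc2c1`) chloro and compound 3 (`Brc1ccc2[nH]c(-c3cn(-c4ccccc4)nc3-c3ccccc3)nc2c1`) bromo. In a functional assay on A549 cells (Homo sapiens) for antiproliferative activity, read by MTT assay, with a stated time of 48 h (on this read-out lower numbers stand for stronger inhibition and higher numbers for weaker inhibition), compound 1 gives 1720 nM, compound 2 gives 2370 nM and compound 3 gives 1810 nM. Compound 2 therefore stands within the scatter of both other compounds.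

The next compound, compound 4 (`Cc1ccc2[nH]c(-c3cn(-c4ccccc4)nc3-c3ccccc3)nc2c1`), has methyl in place of chloro on an aromatic carbon. The closest evidence comes from the halogen swaps at this same place, which show a 1.4-fold higher number from compound 1 to compound 2 (0.14 log units; within the scatter), a 1.3-fold lower number from compound 2 to compound 3 (0.12 log units; within the scatter) and a 1.1-fold higher number from compound 1 to compound 3 (0.02 log units; within the scatter). None of these steps leaves the scatter, but no methyl has yet been measured here, so this evidence is only indirect.

No step beyond the scatter is therefore expected in this assay, and the expected step is a 1.1-fold lower number from compound 2 to compound 4 (0.05 log units; within the scatter). For compound 4 the estimated value is 2100 nM, with an expected range of 1000 nM to 4200 nM.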

Compound 4, half-maximal inhibitory concentration: 3610 nM
Estimate against measurement, compound 4: 1.7-fold (0.24 log units) below, within the range that was stated.
By their numbers in this assay, from the lowest: compounds 1, 3, 2 and 4 (each within the scatter of the next, the first and the last beyond it).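

Methyl is the only group shown at this position that is not a halogen, and replacing chloro with it gives a 1.5-fold higher number from compound 2 to compound 4 (0.18 log units; within the scatter) in this assay while replacing bromo with it gives a 2.0-fold higher number from compound 3 to compound 4 (0.30 log units; within the scatter) on the same read-out. Among the compounds shown here, only the replacement of fluoro leaves the scatter, with a 2.1-fold higher number from compound 1 to compound 4 (0.32 log units; beyond the scatter) as the one modest step at this position, so the change can be read beyond the scatter for this single pair alone. No measurement shown here explains that step.

The compounds shown leave open how an amine, a methoxy group or a carboxylic acid would read at this position, and whether a longer chain such as ethyl would sit with methyl. They also leave open whether these replacements would read alike elsewhere on the shared core.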